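Benzyl triazole series: bromo to methoxy on the benzyl ring

The source may hold more compounds than are shown below. What is called first, only, known or untested is meant among the compounds shown, and "the series" means these compounds.

Measured so far:
compound 1 `Brc1ccc(Cn2cc(CSc3nnc(-c4ccccc4)c(-c4ccccc4)n3)nn2)cc1`, 22000 nM
compound 2 `c1ccc(Cn2cc(Cc3nnc(-c4ccccc4)c(-c4ccccc4)n3)nn2)cc1`, 15600 nM

In a functional assay on PC-3 cells (Homo sapiens) for antiproliferative activity, read by MTT assay, with a stated time of 48 h (on this read-out lower numbers stand for stronger inhibition and higher numbers for weaker inhibition), compound 1 gives 22000 nM, the highest of the two numbers recorded; compound 2 gives 15600 nM, a difference within the scatter, so the two values are treated as alike.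

Compound 3 `COc1ccc(Cn2cc(CSc3nnc(-c4ccccc4)c(-c4ccccc4)n3)nn2)cc1` differs from compound 1 by methoxy in place of bromo on an aromatic carbon. Among the measured compounds shown here, no measured pair shows this exchange, so no direction is supported by data; the expected step from compound 1 to compound 3 is a 1.1-fold lower number from compound 1 to compound 3 (0.04 log units; within the scatter), not beyond the scatter. For compound 3 the expected value in this assay is 20000 nM, with a range from 8000 nM to 50000 nM.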

Compound 3, half-maximal inhibitory concentration: 27500 nM
The estimate for compound 3 lay 1.4-fold (0.14 log units) below the measured number; the measured number falls inside the stated range.
By their numbers in this assay, from the lowest: compounds 2, 1 and 3 (each within the scatter of the next).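

Methoxy in place of bromo on an aromatic carbon, para to a large group, gives in this assay a 1.3-fold higher number from compound 1 to compound 3 (0.10 log units; within the scatter) and thus supplies a measured step for this exchange, which the earlier compounds did not. At this position on the benzyl ring, the 4-bromobenzyl and 4-methoxybenzyl groups cannot be told apart on this read-out. No available measurement bears on the reason for this result.

As far as these compounds go, whether an amine, a carboxylic acid or a longer chain at this position would shift the number beyond the scatter remains open.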